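The source may report more compounds than this note shows. Statements on the series, on what has been measured and on what is new or still open speak of the compounds shown alone.

Compound 1 `C=C1C(=O)[C@H]2C[C@@H]1CC1=C2[C@]2(C)CCC[C@](C)(CO)[C@H]2CC1` in an ADME assay on RWPE-1 cells (Homo sapiens) for cytotoxicity, read by MTT assay, with a stated time of 24 h (a lower number here means a stronger inhibitor, a higher number a weaker inhibitor), reaches only the limit > 50000 nM.
Compound 2 `C[C@@H]1C(=O)[C@H]2C[C@]1(O)CC1=C2[C@]2(C)CCC[C@](C)(CO)[C@H]2CC1` in this assay likewise sits at the limit > 50000 nM.
Compound 3 `C[C@@H]1C(=O)[C@H]2C[C@]1(O)CC1=C2[C@]2(C)CCCC(C)(C)[C@H]2CC1` in this assay also stops at the limit > 50000 nM.

For the measured compounds named here, every measured value is a limit of this assay, so no compound is ordered against another; the one step that can be drawn, a step that the two limits leave unreadable from compound 2 to compound 3, is unreadable for that reason (the limit of > 50000 nM in this assay, at which 3 of the 3 values shown sit). Compound 3 therefore stands at the limit together with the two other measured compounds, with no number to its name.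

The unmeasured compound 4 `C[C@@H]1C(=O)[C@H]2C[C@]1(O)CC1=C2[C@]2(C)CCC[C@@](C)(CO)[C@H]2CC1` differs from compound 3 by hydroxy in place of hydrogen on a saturated chain carbon bound to a saturated ring carbon. Going by the values given here, the only step that touches a hydroxy on a saturated chain carbon bound to a saturated ring carbon is the one from compound 2 to compound 3, and it is unreadable, while compound 4 is not the same structure as compound 2. No readable step exists for guidance, so the step from compound 3 to compound 4 is expected to be a step that the limit leaves unreadable from compound 3 to compound 4, that is, no change beyond the scatter. Compound 4 is expected to give 60000 nM, in the range 20000 nM to 200000 nM, most likely again reported as a limit.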

Compound 4, half-maximal inhibitory concentration: > 50000 nM
Compound 4: a limit, no number (the forecaster's own chance of this, stated with the estimate: 85%); the middle value lies beyond the limit too.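

Neither step reaching compound 4, from compound 2 or from compound 3, can be read: the limit of > 50000 nM in this assay, at which 4 of the 4 values shown sit.

Left open is whether any change to the shared core gives a number in this assay at all, and how these compounds order against one another.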